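The source may report more compounds than this note shows. Statements on the series, on what has been measured and on what is new or still open speak of the compounds shown alone.

In a functional assay on the whole organism (Peritoneal cavity) with Rattus norvegicus as the target (a higher number here means that more compound is needed for the effect, a lower number that less compound is needed), compound 1 `CC(C)(/C=N/OCC(=O)O)Cc1c(SC(C)(C)C)c2cc(OCc3ccc4ccccc4n3)ccc2n1Cc1ccc(Cl)cc1` gives 0.24 umol/kg and compound 2 `CC(C)(/C=N/OCC(=O)O)Cc1c(SC(C)(C)C)c2cc(OCc3cccc(Cl)n3)ccc2n1Cc1ccc(Cl)cc1` gives 2.6 umol/kg, the higher of the two numbers. Compound 3 `CC(C)(C)Sc1c(CC(C)(C)C(=O)O)n(Cc2ccc(Cl)cc2)c2ccc(OCc3cccc(Cl)n3)cc12` keeps the 6-chloropyridin-2-yl group of compound 2 but differs elsewhere: a group of 3 heavy atoms (1 carbon, 2 oxygen; no ring) in place of a group of 7 heavy atoms (3 carbon, 1 nitrogen, 3 oxygen; no ring), on a saturated chain carbon bound to three saturated chain carbons. Going by the values given here, the only measured step, an 11-fold higher number from compound 1 to compound 2 (1.03 log units; beyond the scatter), is large, but it comes from 6-chloropyridin-2-yl in place of quinolin-2-yl, not from this change. It shows that this assay can respond strongly to a single change, yet it gives no direction here, so no step beyond the scatter is expected, and the estimated step is a 1.2-fold higher number from compound 2 to compound 3 (0.06 log units; within the scatter). For compound 3 the expected value is 3 umol/kg, with a wide estimated range of 0.7 umol/kg to 13 umol/kg.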

Compound 3, dose for half-maximal effect: 1.2 umol/kg
Beside the measured number, compound 3's estimate is 2.5-fold (0.40 log units) above it; low and high end bracket the measured number.
By their numbers in this assay, from the lowest: compound 1; then compound 3; then compound 2.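

Carboxy in place of the group of 7 heavy atoms, on a saturated chain carbon bound to three saturated chain carbons, gives a 2.2-fold lower number from compound 2 to compound 3 (0.34 log units; beyond the scatter) in this assay for this pair. This position therefore affects the dose needed, and the group of 7 heavy atoms is not required for the effect here. No measurement shown explains why the number falls.

Going by these compounds, it remains open whether carboxy would give a similar step alongside quinolin-2-yl instead of 6-chloropyridin-2-yl. On these data alone, how an amide or a longer chain ending in a carboxylic acid would behave on this carbon also remains open.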